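Aryl change on the oxadiazole: from trifluorophenyl to chlorophenyl

The source may hold more compounds than are shown below. What is called first, only, known or untested is meant among the compounds shown, and "the series" means these compounds.

Compound 1 `CC(C)(C)n1ncc(OCc2nnc(-c3cccc(F)c3)o2)c(Cl)c1=O`: in a functional assay on the whole organism for inhibition, with Mythimna separata as the target, with a stated time of 5 days (a higher number here means that more compound is needed for the effect, a lower number that less compound is needed), compound 1 gives 7100 nM.
Compound 2 `CC(C)(C)n1ncc(OCc2nnc(-c3cc(F)c(F)cc3F)o2)c(Cl)c1=O`: in this assay compound 2 gives 75700 nM.

Compound 2 stands at the highest of the two numbers in this assay; its nearest neighbour is compound 1, and the step of an 11-fold higher number from compound 1 to compound 2 (1.03 log units; beyond the scatter) was large and beyond the scatter. Compound 3 `CC(C)(C)n1ncc(OCc2nnc(-c3ccc(Cl)cc3)o2)c(Cl)c1=O` differs from compound 2 by 4-chlorophenyl in place of 2,4,5-trifluorophenyl on an aromatic carbon. Among the compounds with values here, no measured step covers a chlorine on the phenyl ring, so only the step of an 11-fold higher number from compound 1 to compound 2 (1.03 log units; beyond the scatter) bears on this change, and it bears only indirectly: it shows that the phenyl ring with one fluorine gave a much lower number than the ring with three. Since compound 3 carries a single halogen on the ring, the number in this assay is expected to move back toward that of compound 1, by a step of about a 7.6-fold lower number from compound 2 to compound 3 (0.88 log units; beyond the scatter). For compound 3 the estimate in this assay is 10000 nM, with a range from 3000 nM to 40000 nM.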

Compound 3, half-maximal effective concentration: 1900 nM
Compound 3: middle estimate off by 5.3-fold (0.72 log units), on the high side, and the stated range ends above it.
By their numbers in this assay, from the lowest: compound 3; then compound 1; then compound 2.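

In this assay, 4-chlorophenyl gave the lowest number of the three groups at this aromatic carbon of the five-membered ring, with a 40-fold lower number from compound 2 to compound 3 (1.60 log units; beyond the scatter) and a 3.7-fold lower number from compound 1 to compound 3 (0.57 log units; beyond the scatter). The earlier pair had shown only that 3-fluorophenyl gave a lower number than 2,4,5-trifluorophenyl; this result shows that the number at this carbon can fall further and that the two groups with a single halogen do not stand level. Nothing available explains these differences.

Compound 1 and compound 3 differ in both the halogen and its place on the phenyl ring, so the two contributions cannot be separated. As far as these compounds go, it also remains open how 4-fluorophenyl, 3-chlorophenyl, unsubstituted phenyl or 4-methoxyphenyl would stand at this carbon.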